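Swapping Naphthalen-1-yl for 1-Phenylethyl on the Amide Nitrogen

A few compounds are considered here, and "the series" means these few. Any claim that something is new, unique, unknown or untested is made for them only; others in the source may bear on it.

Compound 1 `N=C(N)Nc1cccc(C(=O)NCC(=O)N[C@@H](CC(=O)O)C(=O)Nc2ccccc2)c1` gives 13 nM in an assay on a protein complex for binding affinity to integrin alpha-5/beta-1 (Homo sapiens), read by ELISA, with a stated time of 1 h; on this read-out higher numbers stand for weaker inhibition and lower numbers for stronger inhibition.
Compound 2 `N=C(N)Nc1cccc(C(=O)NCC(=O)N[C@@H](CC(=O)O)C(=O)NCc2ccccc2)c1` gives 31 nM in this assay.
Compound 3 `N=C(N)Nc1cccc(C(=O)NCC(=O)N[C@@H](CC(=O)O)C(=O)Nc2cccc3ccccc23)c1` gives 22 nM in this assay.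

For the measured compounds named here, compound 3 sits in the middle of these three numbers, yet neither neighbour is clearly apart from it: a 1.4-fold lower number from compound 2 to compound 3 (0.15 log units; within the scatter) and a 1.7-fold higher number from compound 1 to compound 3 (0.23 log units; within the scatter), so all three read as essentially alike in this assay, with the only step that stands out being a 2.4-fold higher number from compound 1 to compound 2 (0.38 log units; beyond the scatter).

Compound 4 `C[C@@H](NC(=O)[C@H](CC(=O)O)NC(=O)CNC(=O)c1cccc(NC(=N)N)c1)c1ccccc1` is not yet measured. Its change from compound 3 is 1-phenylethyl in place of naphthalen-1-yl on an amide-type nitrogen. Going by the values given here, the closest precedent is the pair of compound 2 and compound 3, where a 1.4-fold lower number from compound 2 to compound 3 (0.15 log units; within the scatter) shows that a one-carbon link between the amide nitrogen and the phenyl ring made little difference against naphthalen-1-yl. The step of a 2.4-fold higher number from compound 1 to compound 2 (0.38 log units; beyond the scatter) suggests that moving the ring one atom away from the nitrogen can raise the number modestly. Among the compounds with values here, the new group carries a methyl on that link, for which no precedent exists here. A small step upward, or none beyond the scatter, is expected in this assay. Compound 4 is therefore estimated at 30 nM, with a range from 12 nM to 80 nM. The expected step of a 1.4-fold higher number from compound 3 to compound 4 (0.13 log units; within the scatter) would stay within the usual scatter.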

Compound 4, half-maximal inhibitory concentration: 45 nM
For compound 4 the middle estimate is 1.5-fold (0.18 log units) below the measured one, and the stated range covers the measured number.
By their numbers in this assay, from the lowest: compounds 1, 3, 2 and 4 (each within the scatter of the next, the first and the last beyond it).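

The methyl added to the saturated chain carbon bound to the amide-type nitrogen and the aromatic carbon changes little in this assay (a 1.5-fold higher number from compound 2 to compound 4 (0.16 log units; within the scatter)), so on this evidence the benzyl and 1-phenylethyl groups read as alike at this position. The other two comparisons differ: the new group stands apart from naphthalen-1-yl (a 2.0-fold higher number from compound 3 to compound 4 (0.31 log units; beyond the scatter)), which benzyl did not do, and from phenyl (a 3.5-fold higher number from compound 1 to compound 4 (0.54 log units; beyond the scatter)), so 1-phenylethyl and benzyl both sit clearly apart from phenyl, while naphthalen-1-yl sits within the scatter of phenyl and of benzyl. No measurement is available that explains why these groups differ.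

Still open, from the compounds shown here alone, is what the other form of the stereocentre in 1-phenylethyl would give, since only one form appears here. Also open, going by these compounds, is whether a longer chain such as 2-phenylethyl, or a phenyl ring carrying an amine or a carboxylic acid, would stay close to compound 1 or follow compound 4.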